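The source may hold more compounds than are shown below. What is called first, only, known or untested is meant among the compounds shown, and "the series" means these compounds.

Compound 1 `CNC(=O)c1ccccc1Oc1nc(Nc2ccc(Br)cc2)ncc1Br` and compound 2 `CNC(=O)c1ccccc1Oc1nc(Nc2cccc(C(F)(F)F)c2)ncc1Br` share one core and differ only in the substituent on the aniline ring, a bromine in compound 1 against a trifluoromethyl in compound 2. In a functional assay on A549 cells (Homo sapiens) for antiproliferative activity, read by MTT assay, with a stated time of 24 h (a lower number here means a stronger inhibitor, a higher number a weaker inhibitor), compound 1 gives 23500 nM, and in this assay compound 2 gives 28300 nM. Compound 2 thus stands with the higher of the two numbers, but its nearest neighbour, compound 1, lies within the scatter of it, so the two readings show no ordering.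

Compound 3 `CNC(=O)c1ccccc1Oc1nc(Nc2cccc(OC)c2)ncc1Br` follows from compound 2 by a single change, (methoxy in place of trifluoromethyl on an aromatic carbon). Among the measured compounds shown here, no measured pair in this set shows what such a swap does to this assay, and the two available numbers are close to each other, so there is no ground to expect a step beyond the scatter in either direction. Compound 3 is therefore expected to sit near compound 2, with a step of a 1.1-fold lower number from compound 2 to compound 3 (0.05 log units; within the scatter) that amounts to no change worth noting. The estimate for compound 3 in this assay is 25000 nM, with a range from 10000 nM to 60000 nM.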

Compound 3, half-maximal inhibitory concentration: 6230 nM
The estimate for compound 3 lay 4.0-fold (0.60 log units) above the measured number; the measured number lies below the stated range.
By their numbers in this assay, from the lowest: compound 3; then compounds 1 and 2 (each within the scatter of the next).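

In this assay, among the compounds shown here, methoxy in place of trifluoromethyl on this aromatic carbon gives a 4.5-fold lower number from compound 2 to compound 3 (0.66 log units; beyond the scatter), the first step in the set that lies beyond the scatter, so the reading does respond to the group held at this place, which the two earlier compounds, within the scatter of each other, could not show. The change of 3-methoxyphenyl in place of 4-bromophenyl on the nitrogen gives a 3.8-fold lower number from compound 1 to compound 3 (0.58 log units; beyond the scatter), also modest, and this step alters both the group and where it stands on the ring, so it cannot be assigned to either alone. Compound 3 therefore holds the lowest number of the three, and nothing available here bears on why the methoxy compound reads lower.

The compounds shown leave open whether the oxygen of the methoxy matters to this step, which a hydroxyl or an ethoxy at the same place would help to test. They also leave open whether an amine or a longer ether chain there would carry the number further down or return it to the level of compound 2.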